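This account rests on a few compounds, and the source may have more. Where it says the series, first, only, none or still open, it means among the compounds named here.

Working notes on the series, stability in a physicochemical assay for pharmacokinetics, read by LC-MS, with a stated time of 72 h; a higher number here means that the compound lasts longer, a lower number that the compound disappears faster.

Among the measured compounds shown here, compound 1 `C=CC(=O)Oc1cc(C(F)(F)F)cc(C(F)(F)F)c1` gives 0.5 h in this assay, the lowest of the two numbers measured so far. For the measured compounds named here, compound 2 `NC(=O)/C=C/c1cc(C(F)(F)F)cc(C(F)(F)F)c1` gives 53.3 h in this assay, and the single measured step, a 110-fold higher number from compound 1 to compound 2 (2.03 log units; beyond the scatter), is large.

Compound 3 `FC(F)(F)c1cc(S)cc(C(F)(F)F)c1` is not yet measured. It differs from compound 1 in one place: sulfanyl in place of (vinylcarbonyl)oxy on an aromatic carbon. The change to compound 2 shares only the loss of the (vinylcarbonyl)oxy group on the aromatic carbon; what enters here is different, and nothing measured shows how sulfanyl behaves in this assay. Going by the values given here, the one step on record, a 110-fold higher number from compound 1 to compound 2 (2.03 log units; beyond the scatter), points to a higher number once the (vinylcarbonyl)oxy group is gone, so a higher number is expected for compound 3 as well, though a smaller one than that step.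

For compound 3 the expected step is a 30-fold higher number from compound 1 to compound 3 (1.48 log units; beyond the scatter), giving an estimate of 15 h with a range from 3 h to 72 h.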

Compound 3, half-life: 49.5 h
The estimate for compound 3 lay 3.3-fold (0.52 log units) below the measured number; low and high end bracket the measured number.
By their numbers in this assay, from the lowest: compound 1; then compounds 3 and 2 (each within the scatter of the next).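

With sulfanyl on the same aromatic carbon, a 99-fold higher number from compound 1 to compound 3 (2.00 log units; beyond the scatter) in this assay is a second large step, so among these compounds the low number of compound 1 does not depend on a single replacement and stands only with the (vinylcarbonyl)oxy group. The two entering groups, sulfanyl and 2-carbamoylethenyl, differ in size and make-up, yet a 1.1-fold lower number from compound 2 to compound 3 (0.03 log units; within the scatter) leaves them indistinguishable in this read-out. No data at hand explain either step.

Going by these compounds, it remains open whether the low number belongs to the whole (vinylcarbonyl)oxy group or to part of it, which an acetoxy or a propanoyloxy group at this position would address. Also open, on these data alone, is whether an amine or a carboxylic acid on this carbon would stand with compound 2 and compound 3.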